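The source may report more compounds than this note shows. Statements on the series, on what has been measured and on what is new or still open speak of the compounds shown alone.

Compound 1 `N=C(N)c1ccc(O)c(CCCNC(=O)c2ccc(-c3ncc[nH]3)cc2)c1` in an assay on isolated protein for inhibition of serine protease 1 (Homo sapiens) (on this read-out lower numbers stand for stronger inhibition and higher numbers for weaker inhibition), gives about 2900 nM. Compound 2 `N=C(N)c1ccc(O)c(/C=C/CNC(=O)c2ccc(-c3cccc(C(N)=O)c3)cc2)c1` in this assay gives > 2900 nM, which is a limit of the assay and not a number, namely (the limit of > 2900 nM in this assay, at which 1 of the 2 values shown sits). Compound 3 `N=C(N)c1ccc(O)c(/C=C/CNC(=O)c2ccc(-c3ccnc(C(N)=O)c3)cc2)c1` differs from compound 2 in one place: 2-carbamoylpyridin-4-yl in place of 3-carbamoylphenyl on an aromatic carbon. No measured step of this kind exists among the compounds shown, so the expected step, a step that the limit leaves unreadable from compound 2 to compound 3, is taken as small and in no direction beyond the usual scatter. Compound 3 is therefore estimated at 4000 nM, with a likely range from 1500 nM to 12000 nM.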

Compound 3, inhibition constant: 2200 nM
Estimate against measurement, compound 3: 1.8-fold (0.26 log units) above; measured number inside the range.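

Placing 2-carbamoylpyridin-4-yl in place of 3-carbamoylphenyl, on an aromatic carbon para to a large group, gives in this assay an at least 1.3-fold lower number from compound 2 to compound 3 (0.11 log units; that floor lies within the scatter). The value of compound 2, > 2900 nM, is a limit of the assay and not a number. The step is therefore only a floor, but it shows that this position can carry a six-membered aromatic ring with 1 hetero atom and still give a readable number. From the compounds shown here alone, how large the step truly is stays open, as does whether a carboxylic acid or an amine in place of the carbamoyl group of compound 3 would move the number beyond the scatter.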